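The source may report more compounds than this note shows. Statements on the series, on what has been measured and on what is new or still open speak of the compounds shown alone.

In a functional assay on DU-145 cells (Homo sapiens) for inhibition, read by trypan blue exclusion, with a stated time of 96 h (a higher number here means a weaker inhibitor of growth, a lower number a stronger inhibitor of growth), compound 1 `O=C(/C(=C\c1c[nH]c2ccccc12)SCc1ccc(F)cc1)c1ccc(Cl)cc1` gives 1000 nM and compound 2 `CN(C)c1ccc(/C=C(/SCc2ccc(F)cc2)C(=O)c2ccc(Br)cc2)cc1` gives 50000 nM while compound 3 `O=C(/C(=C\c1ccc(Br)cc1)SCc1ccc(F)cc1)c1ccc(Cl)cc1` gives 9000 nM which places compound 3 in the middle of the three numbers, beyond the scatter from both neighbours. Compound 4 `CN(C)c1ccc(/C=C(/SCc2ccc(F)cc2)C(=O)c2ccc(Cl)cc2)cc1` follows from compound 3 through the change dimethylamino in place of bromo on an aromatic carbon with dimethylamino in place of bromo on an aromatic carbon. Within the data shown here, the one measured step at this place is a 9.0-fold higher number from compound 1 to compound 3 (0.95 log units; beyond the scatter) and it lies beyond the scatter, so the number in this assay can move with the group held here, although that step involves no dimethylamino. The 4-(dimethylamino)phenyl of compound 4 is also present in compound 2 with 50000 nM as the highest of the three numbers. A modest step toward a higher number is therefore expected, no larger than the measured one. The estimated step is a 3.3-fold higher number from compound 3 to compound 4 (0.52 log units; beyond the scatter) on this reasoning. The estimated value for compound 4 is 30000 nM with an expected range of 10000 nM to 80000 nM in this series.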

Compound 4, concentration for 50% growth inhibition: 50000 nM
Compound 4: middle estimate off by 1.7-fold (0.22 log units), on the low side; low and high end bracket the measured number.
By their numbers in this assay, from the lowest: compound 1; then compound 3; then compounds 2 and 4 (each within the scatter of the next).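

In this assay the step at this position, a 5.6-fold higher number from compound 3 to compound 4 (0.74 log units; beyond the scatter), gives a direct reading for dimethylamino in place of bromo on an aromatic carbon para to a large group, and the number moves beyond the scatter. With the 4-(dimethylamino)phenyl held in place, chloro in place of bromo on the other aromatic ring shows no change at the digits printed from compound 2 to compound 4 (within the scatter), so this halogen exchange leaves the number unmoved in this pair. Against the 1H-indol-3-yl of compound 1, the same group gives a 50-fold higher number from compound 1 to compound 4 (1.70 log units; beyond the scatter), a larger step than the one for 4-bromophenyl.

No measurement on hand accounts for these steps. Still open, as far as these compounds go, is how a primary amine or a methoxy group at this position would compare with bromo and dimethylamino, and whether chloro and bromo also match when 4-bromophenyl is held in place.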